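Swapping a Benzothiophene for a Benzofuran on a Spirocyclic Lactone

The compounds below may be only part of what the source reports. "The series", "measured", "known", "first", "only" and "open" are said of these compounds alone.

Measured compounds:
Compound 1 `O=C1C=CC2(C=C1)OC(=O)C(I)=C2c1ccccc1`: 41500 nM
Compound 2 `O=C1C=CC2(C=C1)OC(=O)C(c1cc3ccccc3s1)=C2c1ccccc1`: 5900 nM

Both values come from a functional assay on MCF7 cells (Homo sapiens) for antiproliferative activity, read by MTT assay, with a stated time of 48 h; a higher number here means a weaker inhibitor, a lower number a stronger inhibitor. Compound 2 gives the lowest number of the two; its nearest neighbour is compound 1, and the step of a 7.0-fold lower number from compound 1 to compound 2 (0.85 log units; beyond the scatter) shows what replacing the iodo group by a 1-benzothiophen-2-yl group did on the shared core.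

Compound 3 `O=C1C=CC2(C=C1)OC(=O)C(c1cc3ccccc3o1)=C2c1ccccc1` is not yet measured. It differs from compound 2 in one place: 1-benzofuran-2-yl in place of 1-benzothiophen-2-yl on a double-bonded ring carbon. The two groups are alike in size and shape; only the single hetero atom of the five-membered ring changes, sulfur in compound 2 and oxygen in compound 3.

Going by the values given here, no measured step here exchanges one aromatic hetero atom for another, so the only step on record, from compound 1 to compound 2, bears on this change only indirectly: it says that a fused bicyclic aromatic group at this position is tolerated well, not how sulfur compares with oxygen. In this assay the expected step of a 1.3-fold higher number from compound 2 to compound 3 (0.10 log units; within the scatter) is therefore small, most likely within the scatter, with a slight lean towards a higher number. Compound 3 is expected to give about 7500 nM, with a likely range from 2500 nM to 22000 nM.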

Compound 3, half-maximal inhibitory concentration: 5800 nM
Estimate against measurement, compound 3: 1.3-fold (0.11 log units) above; low and high end bracket the measured number.
By their numbers in this assay, from the lowest: compounds 3 and 2 (each within the scatter of the next); then compound 1.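

In this assay, changing the hetero atom of the five-membered aromatic ring gives a 1.0-fold lower number from compound 2 to compound 3 (0.01 log units; within the scatter) and so sulfur and oxygen cannot be told apart at this position on the shared core. The earlier drop from the iodo compound now has a second example: a 7.2-fold lower number from compound 1 to compound 3 (0.85 log units; beyond the scatter) stands alongside a 7.0-fold lower number from compound 1 to compound 2 (0.85 log units; beyond the scatter) and shows that 1-benzofuran-2-yl and 1-benzothiophen-2-yl both separate from iodo to a matching degree. No measurement of any property of these groups is available to account for this match.

The compounds shown leave open how far this tolerance extends to other groups at this place, such as a plain phenyl, a single thiophene or furan ring, or a fused aromatic group carrying an amine or a carboxylic acid. They also leave open whether nitrogen in the five-membered ring, as in an indol-2-yl group, would behave like sulfur and oxygen, and whether any group here can give a lower number than compound 3 at 5800 nM in this assay.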